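Shortening the saturated chain on the core of compound 1

The source may report more compounds than this note shows. Statements on the series, on what has been measured and on what is new or still open speak of the compounds shown alone.

Compound 1 `CCCCCCCCCCCCCC1=CC(=O)C=C(OC)C1=O` gives 1050 nM in an assay on isolated protein for inhibition of Polyunsaturated fatty acid 5-lipoxygenase (Homo sapiens), read by ELISA, with a stated time of 10 min; a higher number here means a weaker inhibitor, a lower number a stronger inhibitor. Compound 2 `CCCCCCCCCCCCCc1cc(O)cc(OC)c1O` gives 1490 nM in this assay, and compound 3 `CCCCCc1cc(O)cc(OC)c1O` gives 940 nM. Compound 1 thus holds the second highest of the three numbers; its nearest neighbour is compound 3, within the scatter, and its furthest is compound 2, also within the scatter, so no order can be read among the three. Compound 4 `CCCCCCCCCCCC1=CC(=O)C=C(OC)C1=O` differs from compound 1 by hydrogen in place of ethyl on a saturated chain carbon, ten or more bonds along the chain from a double-bonded ring carbon. For the measured compounds named here, no measured pair shows this change, so the size of the step is open; the expected step from compound 1 to compound 4 is a 1.0-fold higher number from compound 1 to compound 4 (0.02 log units; within the scatter), none beyond the scatter. Compound 4 is estimated at 1100 nM, between 550 nM and 2200 nM.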

Compound 4, half-maximal inhibitory concentration: 340 nM
Compound 4: the middle estimate sits 3.2-fold (0.51 log units) above what was measured, outside the stated range (below it).
By their numbers in this assay, from the lowest: compound 4; then compounds 3, 1 and 2 (each within the scatter of the next).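

Hydrogen in place of ethyl on a saturated chain carbon gives a 3.1-fold lower number from compound 1 to compound 4 (0.49 log units; beyond the scatter) in this assay. For the compounds shown here, this is the first step beyond the scatter, so this far chain position does register in the read-out. Nothing available explains the step.

Going by these compounds, whether a shorter or a longer chain on the same core would continue this direction stays open. So does the effect of an amine or a carboxylic acid at this position.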